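Relocating the Nitro Group on the Benzyl Ether

The source may report more compounds than this note shows. Statements on the series, on what has been measured and on what is new or still open speak of the compounds shown alone.

The pair measured so far shares one core and differs only in the substituent on the benzyl ring. Compound 1 `COc1cccc(OC)c1OCCNCCOc1ccccc1OCc1ccccc1C` carries a methyl there and in an assay on CHO cells for displacement of a labelled ligand from Alpha-1B adrenergic receptor (Homo sapiens) (on this read-out lower numbers stand for stronger inhibition and higher numbers for weaker inhibition), compound 1 gives 0.794 nM. Compound 2 `COc1cccc(OC)c1OCCNCCOc1ccccc1OCc1ccccc1[N+](=O)[O-]` carries a nitro group instead, and in this assay compound 2 gives 2.51 nM, so that the change a 3.2-fold higher number from compound 1 to compound 2 (0.50 log units; beyond the scatter). Compound 2 therefore stands as the higher of the two numbers recorded, with compound 1 below it.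

Compound 3 `COc1cccc(OC)c1OCCNCCOc1ccccc1OCc1ccc([N+](=O)[O-])cc1` keeps every atom of compound 2 but joins them differently: 4-nitrophenyl in place of 2-nitrophenyl on a saturated chain carbon bound to an oxygen on an aromatic ring. For the measured compounds named here, no measured step in this set moves a group around the ring; the only step at hand, a 3.2-fold higher number from compound 1 to compound 2 (0.50 log units; beyond the scatter), concerns an exchange of one group for another at a single position, so it offers no direct guide. With the same atoms kept and only their arrangement on the ring altered, a step of modest size or none beyond the scatter is expected in this assay, with a slight lean toward a higher number.

Compound 3 is thus estimated to give 4 nM in this assay, within a range from 1 nM to 16 nM, which would mean a step of a 1.6-fold higher number from compound 2 to compound 3 (0.20 log units; within the scatter).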

Compound 3, inhibition constant: 0.398 nM
Compound 3: the middle estimate sits 10-fold (1.00 log units) above what was measured, outside the stated range (below it).
By their numbers in this assay, from the lowest: compounds 3 and 1 (each within the scatter of the next); then compound 2.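

Keeping every atom and moving only the nitro group is enough to shift the read-out in this assay: 4-nitrophenyl in place of 2-nitrophenyl gives a 6.3-fold lower number from compound 2 to compound 3 (0.80 log units; beyond the scatter) on the saturated chain carbon bound to an oxygen on an aromatic ring. The earlier exchange of methyl for nitro could be read as a penalty for the nitro group itself, but this result shows that the outcome at this position depends on where the group sits on the ring as well as on which group is present. Set against the methyl compound, 4-nitrophenyl in place of 2-methylphenyl gives a 2.0-fold lower number from compound 1 to compound 3 (0.30 log units; within the scatter) and so leaves the two compounds indistinguishable in this measurement, while nothing available explains the effect of the relocation.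

Whether a methyl group would respond to relocation as the nitro group does remains open, as the methyl appears in a single arrangement among these compounds. The compounds shown also leave open how an amine or a carboxylic acid in place of the nitro group on this ring would read in this assay at either arrangement.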